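This account rests on a few compounds, and the source may have more. Where it says the series, first, only, none or still open, it means among the compounds named here.

Notes on the series. In a functional assay on MDA-MB-468 cells (Homo sapiens) for cytotoxicity, with a stated time of 48 h (on this read-out higher numbers stand for weaker inhibition and lower numbers for stronger inhibition), compound 3 `N#Cc1ccc(-c2cc(COC(Cc3cn(C4CCN(Cc5ccc([N+](=O)[O-])cc5)CC4)nn3)c3ccc(Br)cc3)on2)cc1` gives 5000 nM, level with compound 1 `O=[N+]([O-])c1ccc(CN2CCC(n3cc(CC(OCc4cc(-c5ccc(Br)cc5)no4)c4ccc(Br)cc4)nn3)CC2)cc1`, which gives 5000 nM; together these are the lowest of the three numbers. Among the compounds with values here, compound 2 `COc1ccc(-c2cc(COC(Cc3cn(C4CCN(Cc5ccc([N+](=O)[O-])cc5)CC4)nn3)c3ccc(Br)cc3)on2)cc1` gives 9000 nM in this assay and is the one furthest from compound 3, with a 1.8-fold lower number from compound 2 to compound 3 (0.26 log units; within the scatter). Compound 4 `O=[N+]([O-])c1ccc(CN2CCC(n3cc(CC(OCc4cc(-c5cccc(F)c5)no4)c4ccc(Br)cc4)nn3)CC2)cc1` is the next compound for this assay and differs from compound 3 in one place: 3-fluorophenyl in place of 4-cyanophenyl on an aromatic carbon.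

The measured steps that bear on this change all alter the group at the same place: no change at the digits printed from compound 1 to compound 3 (within the scatter), a 1.8-fold lower number from compound 2 to compound 3 (0.26 log units; within the scatter) and a 1.8-fold higher number from compound 1 to compound 2 (0.26 log units; within the scatter). Each lies within the scatter, so three different groups at this place give indistinguishable numbers in this assay. Nothing measured speaks for a larger movement with 3-fluorophenyl. For compound 4 the expected step in this assay is a 1.1-fold higher number from compound 3 to compound 4 (0.04 log units; within the scatter), none beyond the scatter. The estimate for compound 4 in this assay is 5500 nM, with a range from 2500 nM to 12000 nM.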

Compound 4, half-maximal inhibitory concentration: 3000 nM
Estimate against measurement, compound 4: 1.8-fold (0.26 log units) above; the measured number falls inside the stated range.
By their numbers in this assay, from the lowest: compounds 4, 1, 3 and 2 (each within the scatter of the next, the first and the last beyond it).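

In this assay, within the data shown here, the aromatic carbon next to the ring nitrogen now shows a step beyond the scatter: a 3.0-fold lower number from compound 2 to compound 4 (0.48 log units; beyond the scatter) is the only such step among the four groups at this place, whereas a 1.7-fold lower number from compound 3 to compound 4 (0.22 log units; within the scatter) and a 1.7-fold lower number from compound 1 to compound 4 (0.22 log units; within the scatter) stay within it. Among these compounds, the group here is therefore not wholly without bearing on the number, yet the separation rests on the single pair of compound 2 and compound 4, and 3-fluorophenyl cannot be told apart from 4-cyanophenyl or 4-bromophenyl. Nothing available accounts for this step.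

The change alters the substituent and its place on the phenyl ring together, and the compounds shown do not separate the two; a 4-fluorophenyl group would. Also open, as far as these compounds go, is whether an amine or a carboxylic acid on this phenyl ring, or a saturated ring in its stead, moves the number beyond the scatter relative to compound 1 or compound 3.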